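Adding methyl to compound 1: expected half-life

The source may hold more compounds than are shown below. What is called first, only, known or untested is meant among the compounds shown, and "the series" means these compounds.

Compound 1 `O=C(Sc1cccnc1C(=O)O)c1ccccc1` stands highest of the three measured compounds in a physicochemical assay for pharmacokinetics, at pH 8 (a lower number here means that the compound disappears faster, a higher number that the compound lasts longer), with 60.1 h and serves as the reference. Compound 2 `O=C(Sc1cccnc1C(=O)O)c1cccc(Cl)c1` gives 14.8 h and compound 3 `O=C(Sc1cccnc1C(=O)O)c1cccc(C(F)(F)F)c1` gives 10 h on the same scale. Compound 4 `Cc1ccc(C(=O)Sc2cccnc2C(=O)O)cc1` carries one change from compound 1 (methyl in place of hydrogen on an aromatic carbon): methyl in place of hydrogen on an aromatic carbon, para to a large group. Among the measured compounds shown here, two measured steps bear on this: chloro (a 4.1-fold lower number from compound 1 to compound 2 (0.61 log units; beyond the scatter)) and trifluoromethyl (a 6.0-fold lower number from compound 1 to compound 3 (0.78 log units; beyond the scatter)), both modest, with little between them (a 1.5-fold lower number from compound 2 to compound 3 (0.17 log units; within the scatter)). For the measured compounds named here, no methyl compound has been measured, so their downward direction need not carry over. In this assay the expected step is small (a 1.4-fold higher number from compound 1 to compound 4 (0.15 log units; within the scatter)) and not beyond the scatter. Compound 4 is estimated at 85 h (expected range 40 h to 170 h).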

Compound 4, half-life: 80.1 h
The estimate for compound 4 lay 1.1-fold (0.03 log units) above the measured number; the measured number falls inside the stated range.
By their numbers in this assay, from the lowest: compounds 3 and 2 (each within the scatter of the next); then compounds 1 and 4 (each within the scatter of the next).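

In this assay, methyl para to a large group gives a 1.3-fold higher number from compound 1 to compound 4 (0.12 log units; within the scatter), so a substituent on the six-membered aromatic ring of carbon only does not always bring the step beyond the scatter seen with chloro and trifluoromethyl. The downward direction of those two steps therefore does not hold across the series, and compound 4 is the exception. Nothing available accounts for this difference between the groups.

Going by these compounds, whether an amine, a carboxylic acid or a longer chain at this position would also stay within the scatter of compound 1 remains open.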